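This account rests on a few compounds, and the source may have more. Where it says the series, first, only, none or still open, it means among the compounds named here.

Measured so far:
compound 1 `CCCCCCCCCCCCCCCCCC1OCC(COCCCCCC[N+](C)(C)C)O1`: 2400 nM
compound 2 `CCCCCCCCCCCCCCCCCC1OCC(COC(=O)CCCCC[n+]2ccsc2)O1`: 1100 nM

Within the data shown here, in a functional assay (Oryctolagus cuniculus) for inhibition of platelet-activating factor receptor (Cavia porcellus) (on this read-out higher numbers stand for weaker inhibition and lower numbers for stronger inhibition), compound 1 gives the highest of these two numbers; the only other compound, compound 2, sits lower, by a 2.2-fold lower number from compound 1 to compound 2 (0.34 log units; beyond the scatter). Compound 3 `CCCCCCCCCCCCCCCCCC1OCC(COCCCCCCCC[n+]2ccsc2)O1` differs from compound 1 in one place: a group of 7 heavy atoms (5 carbon, 1 nitrogen, 1 sulfur; one five-membered aromatic ring with 2 hetero atoms) in place of a group of 4 heavy atoms (3 carbon, 1 nitrogen; no ring), on a saturated chain carbon, six bonds along the chain from an oxygen on a saturated carbon. The step from compound 1 to compound 2 is the one that bears on this, as it too brings in a five-membered aromatic ring with 2 hetero atoms, though it changes more than that. A modest shift toward a lower number is therefore expected, about a 2.0-fold lower number from compound 1 to compound 3 (0.30 log units; within the scatter). Compound 3 is estimated at 1200 nM, within 450 nM to 3200 nM.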

Compound 3, half-maximal inhibitory concentration: 3700 nM
Compound 3: middle estimate off by 3.1-fold (0.49 log units), on the low side, outside the stated range (above it).
By their numbers in this assay, from the lowest: compound 2; then compounds 1 and 3 (each within the scatter of the next).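

In this assay, putting the group with a five-membered aromatic ring with 2 hetero atoms in place of the ring-free group, on a saturated chain carbon, gives a 1.5-fold higher number from compound 1 to compound 3 (0.19 log units; within the scatter) and so stays within the usual scatter. At this place, that ring alone brings no readable change. The step of a 2.2-fold lower number from compound 1 to compound 2 (0.34 log units; beyond the scatter) therefore cannot be credited to the ring alone, since that step changes more than the ring. No measurement here accounts for this result.

Still open, on these data alone, is whether a pyridine ring at this place, or a longer chain leading to the ring, would move the number beyond the scatter.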